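The source may hold more compounds than are shown below. What is called first, only, known or untested is meant among the compounds shown, and "the series" means these compounds.

Compound 1 `c1cc(Nc2nccc(-c3ccco3)n2)cc(-n2ccnc2)c1`: 800 nM. Compound 2 `c1cc(Nc2nccc(-c3cccs3)n2)cc(-n2ccnc2)c1`: 300 nM.

Within the data shown here, in a functional assay for inhibition, with Homo sapiens as the target (on this read-out higher numbers stand for weaker inhibition and lower numbers for stronger inhibition), compound 1 holds the higher of the two numbers, and the only measured step, a 2.7-fold lower number from compound 1 to compound 2 (0.43 log units; beyond the scatter), concerns a change elsewhere on the shared core. Compound 3 `c1cc(Nc2nccc(-c3ccco3)n2)cc(OCCn2ccnc2)c1` differs from compound 1 by 2-(1H-imidazol-1-yl)ethoxy in place of 1H-imidazol-1-yl on an aromatic carbon. Among the measured compounds shown here, compound 1 and compound 2 agree at this place, so no measured step speaks to the change. With nothing to set a direction, compound 3 is expected to show a step of about a 1.1-fold higher number from compound 1 to compound 3 (0.05 log units; within the scatter). The estimate for compound 3 is 900 nM, with a wide range from 250 nM to 3000 nM.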

Compound 3, half-maximal inhibitory concentration: 200 nM
For compound 3 the middle estimate is 4.5-fold (0.65 log units) above the measured one; the measured number lies below the stated range.
By their numbers in this assay, from the lowest: compounds 3 and 2 (each within the scatter of the next); then compound 1.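

In this assay, 2-(1H-imidazol-1-yl)ethoxy in place of 1H-imidazol-1-yl gives a 4.0-fold lower number from compound 1 to compound 3 (0.60 log units; beyond the scatter) and so shows that this position, the same in compound 1 and compound 2, responds to change. Both groups carry the five-membered aromatic ring, so the step comes with the added ethoxy link. Nothing on hand accounts for the step.

Going by these compounds, whether a longer chain or an amine in place of the imidazole ring would move the number further stays open. So does whether the ethoxy change holds with the thiophen-2-yl group of compound 2.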